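Aryl replacement on the dihydropyridine core, compound 3

The source may report more compounds than this note shows. Statements on the series, on what has been measured and on what is new or still open speak of the compounds shown alone.

Compound 1 `COC(=O)C1=C(C)N=C(C)/C(=C(\O)OC)C1c1ccccc1Cl` gives the lowest number of the two measured in a functional assay (muscle tissue) with Cavia porcellus as the target (on this read-out lower numbers stand for an effect already at smaller amounts and higher numbers for an effect only at larger amounts of compound), at 2.19 nM. Among the measured compounds shown here, compound 2 `COC(=O)C1=C(C)N=C(C)/C(=C(\O)OC)C1c1cc([N+](=O)[O-])ccc1Cl` gives 30.2 nM in this assay; the step of a 14-fold higher number from compound 1 to compound 2 (1.14 log units; beyond the scatter) is the only measured change on the aryl group. Compound 3 `COC(=O)C1=C(C)N=C(C)/C(=C(\O)OC)C1c1ccc(C#N)cc1` differs from compound 1 by 4-cyanophenyl in place of 2-chlorophenyl on a saturated ring carbon. For the measured compounds named here, no measured step matches this change, and the one change on the aryl group that is known raised the number well beyond the scatter. For compound 3 a higher number is therefore expected, as the step of a 9.1-fold higher number from compound 1 to compound 3 (0.96 log units; beyond the scatter). Compound 3 is estimated at 20 nM, within 4 nM to 100 nM.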

Compound 3, half-maximal effective concentration: 3470 nM
Compound 3: the middle estimate sits 170-fold (2.24 log units) below what was measured; measured number above the stated range.
By their numbers in this assay, from the lowest: compound 1; then compound 2; then compound 3.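

Replacing 2-chlorophenyl with 4-cyanophenyl on the saturated ring carbon costs far more in this assay (a 1600-fold higher number from compound 1 to compound 3 (3.20 log units; beyond the scatter)) than adding nitro to the aryl group while keeping its chlorine (a 14-fold higher number from compound 1 to compound 2 (1.14 log units; beyond the scatter)). This position therefore admits a much wider range of read-outs than the earlier pair showed. No available evidence bears on the reason for this result.

The step changes two things at once, so the loss of chlorine and the arrival of the nitrile cannot be separated. Plain phenyl, 4-chlorophenyl and 2-cyanophenyl would divide the two effects.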